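Methoxy in Place of Methyl: Compound 3 to Compound 4

A few compounds are considered here, and "the series" means these few. Any claim that something is new, unique, unknown or untested is made for them only; others in the source may bear on it.

Of the compounds shown here, three sharing one core have been tested in a functional assay on Molt4/C8 cells (Homo sapiens) for cytotoxicity; on this read-out lower numbers stand for stronger inhibition and higher numbers for weaker inhibition. Compound 1 `O=C(/C=C/C(=O)N1C/C(=C\c2ccccc2)C(=O)/C(=C/c2ccccc2)C1)Nc1ccc(Cl)c(Cl)c1` gives 1700 nM. Compound 2 `O=C(/C=C/C(=O)N1C/C(=C\c2ccccc2)C(=O)/C(=C/c2ccccc2)C1)Nc1ccc([N+](=O)[O-])cc1` gives 31000 nM. Compound 3 `Cc1ccc(NC(=O)/C=C/C(=O)N2C/C(=C\c3ccccc3)C(=O)/C(=C/c3ccccc3)C2)cc1` gives 660 nM, the lowest of the three numbers. The change of a 2.6-fold lower number from compound 1 to compound 3 (0.41 log units; beyond the scatter) was modest, whereas a 47-fold lower number from compound 2 to compound 3 (1.67 log units; beyond the scatter) was large, and an 18-fold higher number from compound 1 to compound 2 (1.26 log units; beyond the scatter) was also large; all three lie beyond the scatter.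

Compound 4 `COc1ccc(NC(=O)/C=C/C(=O)N2C/C(=C\c3ccccc3)C(=O)/C(=C/c3ccccc3)C2)cc1` differs from compound 3 in one place: methoxy in place of methyl on an aromatic carbon. The step from compound 2 to compound 3 changed the same aromatic carbon, replacing nitro with methyl, and moved the number a long way; compound 1 differs at two places of that ring. Going by the values given here, neither step shows methyl against methoxy directly, so the only guide is that a small, uncharged group at this position goes with the lower numbers. A step of a 1.4-fold higher number from compound 3 to compound 4 (0.13 log units; within the scatter) is therefore expected, within or close to the scatter. Compound 4 is estimated to give 900 nM, with a range from 300 nM to 2700 nM.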

Compound 4, half-maximal inhibitory concentration: 1100 nM
The estimate for compound 4 lay 1.2-fold (0.09 log units) below the measured number; measured number inside the range.
By their numbers in this assay, from the lowest: compounds 3, 4 and 1 (each within the scatter of the next, the first and the last beyond it); then compound 2.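

The step of a 1.7-fold higher number from compound 3 to compound 4 (0.22 log units; within the scatter) shows that adding an oxygen to this group, and with it one hydrogen-bond acceptor, brings no change that can be told from the scatter, so methyl and methoxy cannot be ranked here. Methoxy also stands far from nitro at the same aromatic carbon, with a 28-fold lower number from compound 2 to compound 4 (1.45 log units; beyond the scatter) as the step, so two different groups now sit well away from nitro, and the 4-methoxyphenyl group cannot be separated from 3,4-dichlorophenyl, with a 1.5-fold lower number from compound 1 to compound 4 (0.19 log units; within the scatter) as the step. Nothing measured on these compounds accounts for the distance between nitro and the other groups.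

Still open, from the compounds shown here alone, is whether an amine, a carboxylic acid or a longer chain such as ethoxy at this position would fall with methyl and methoxy or with nitro. A single chlorine here would also show what each chlorine of the 3,4-dichlorophenyl group contributes.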